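Reversing the amide on a shared core

The source may hold more compounds than are shown below. What is called first, only, known or untested is meant among the compounds shown, and "the series" means these compounds.

Measured in a functional assay on KBVIN cells (Homo sapiens) for antiproliferative activity, read by sulforhodamine B assay, with a stated time of 3 days; on this read-out higher numbers stand for weaker inhibition of growth and lower numbers for stronger inhibition of growth:
Compound 1 `O=C(c1cccc(Nc2ncc(F)c(Nc3ccc(F)cc3)n2)c1)N1CCCCC1`: 13800 nM
Compound 2 `Cn1ccnc1NC(=O)c1cccc(Nc2ncc(F)c(Nc3ccc(F)cc3)n2)c1`: 13100 nM
Compound 3 `COc1ccc(NC(=O)c2cccc(Nc3ncc(F)c(Nc4ccc(F)cc4)n3)c2)cc1`: 15700 nM

The three measured compounds share one core and differ only in the group attached to the carbonyl carbon. Compound 1 stands second highest of the three; its steps to the others, a 1.1-fold lower number from compound 1 to compound 2 (0.02 log units; within the scatter) and a 1.1-fold higher number from compound 1 to compound 3 (0.06 log units; within the scatter), are within the scatter, as is a 1.2-fold higher number from compound 2 to compound 3 (0.08 log units; within the scatter). Compound 4 `O=C(Nc1cccc(Nc2ncc(F)c(Nc3ccc(F)cc3)n2)c1)c1ccccc1` has not been measured. It differs from compound 1 by benzamido in place of (piperidin-1-yl)carbonyl on an aromatic carbon. For the measured compounds named here, none of the measured steps makes this same change, but all three changes at the carbonyl left the numbers within the scatter of one another, so in this assay no step beyond the scatter is expected. Compound 4 is therefore estimated at 14000 nM, with a range from 5000 nM to 40000 nM, an expected step of a 1.0-fold higher number from compound 1 to compound 4 (0.01 log units; within the scatter).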

Compound 4, concentration for 50% growth inhibition: > 10000 nM
Compound 4 ended at the assay's limit (the forecaster's own chance of this, stated with the estimate: 10%); the middle value is on the limit's open side.
By their numbers in this assay, from the lowest: compounds 2, 1 and 3 (each within the scatter of the next).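

Compound 4 ended at a limit of the assay, so no step to it from compound 1, compound 2 or compound 3 can be read: the limit of > 10000 nM in this assay, at which 1 of the 4 values shown sits.

From the compounds shown here alone, whether benzamido in place of (piperidin-1-yl)carbonyl changes growth inhibition at all, and by how much, stays open.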